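Phenyl for ethyl on the ring carbon: compound 4

This account rests on a few compounds, and the source may have more. Where it says the series, first, only, none or still open, it means among the compounds named here.

In a functional assay on HA22T cells for cytotoxicity against HA22T cell line (Homo sapiens) (on this read-out higher numbers stand for weaker inhibition and lower numbers for stronger inhibition), compound 2 `CCC1C(=O)N(CCCCCCOc2ccc(Cl)cc2)/C(=N\C#N)N1c1ccncc1` gives 5130 nM, the second highest of the three numbers. Compound 1 `N#C/N=C1\N(CCCCCCOc2ccc(Cl)cc2)C(=O)CN1c1ccncc1` gives 3860 nM in this assay and compound 3 `CCC1C(=O)N(CCCCCCCOc2ccc(Cl)cc2)/C(=N\C#N)N1c1ccncc1` gives 6050 nM; each of these lies within the scatter of compound 2, so no order among the three can be read. Both measured steps are small: a 1.3-fold higher number from compound 1 to compound 2 (0.12 log units; within the scatter), and a 1.2-fold higher number from compound 2 to compound 3 (0.07 log units; within the scatter).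

Compound 4 `N#C/N=C1\N(CCCCCCOc2ccc(Cl)cc2)C(=O)C(c2ccccc2)N1c1ccncc1` carries phenyl in place of ethyl on a saturated ring carbon, that is, phenyl in place of ethyl on a saturated ring carbon of a five-membered non-aromatic ring with 2 nitrogen. For the measured compounds named here, only the step from compound 1 to compound 2 touches this carbon, and it swapped hydrogen for ethyl without leaving the scatter. Going by the values given here, no measured step shows what a six-membered aromatic ring of carbon only does at that carbon, so the expectation rests on the flat picture so far and is wide. Compound 4 is expected to give 5000 nM in this assay, with a range from 1800 nM to 14000 nM. The step this estimate means is a 1.0-fold lower number from compound 2 to compound 4 (0.01 log units; within the scatter), expected to stay within the scatter.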

Compound 4, half-maximal inhibitory concentration: 526 nM
Compound 4: the middle estimate sits 9.5-fold (0.98 log units) above what was measured, and the stated range ends above it.
By their numbers in this assay, from the lowest: compound 4; then compounds 1, 2 and 3 (each within the scatter of the next).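

In this assay this saturated ring carbon turns out to be a position that responds: phenyl in place of ethyl gives a 9.8-fold lower number from compound 2 to compound 4 (0.99 log units; beyond the scatter), and phenyl in place of hydrogen gives a 7.3-fold lower number from compound 1 to compound 4 (0.87 log units; beyond the scatter), whereas ethyl in place of hydrogen gave only a 1.3-fold higher number from compound 1 to compound 2 (0.12 log units; within the scatter). The flat picture therefore holds for hydrogen and ethyl alone, and phenyl, with 6 heavy atoms against 2 for ethyl, is the only change shown at this carbon that moves the number beyond the scatter. Nothing available gives a reason for this step.

Open, from the compounds shown here alone, is whether the aromatic ring itself matters or only the added carbon atoms, which a cyclohexyl or benzyl group on the same carbon would separate. Also open, going by these compounds, are whether the step carries over to the longer chain of compound 3 and how a 4-chlorophenyl or pyridyl group behaves there.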